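Swapping Acetyl for Dimethylamino on a Shared Core

A few compounds are considered here, and "the series" means these few. Any claim that something is new, unique, unknown or untested is made for them only; others in the source may bear on it.

Compound 1 `COc1cc(C)cc(-c2c(-c3ccnc(-c4ccc(C(C)=O)cc4)c3)cnn2CC#N)c1` gives 80% in a functional assay on SNB-75 cells (Homo sapiens) for cytotoxicity, read by sulforhodamine B assay, with a stated time of 48 h, tested at 0.001 uM (a higher number here means a weaker effect of the compound at the concentration tested, a lower number a stronger effect), the lowest of the two numbers at hand. Compound 2 `Cc1cc(O)cc(-c2nn(CC#N)cc2-c2ccnc(-c3ccc(N(C)C)cc3)c2)c1` gives 83% in this assay, the nearest number and within the scatter, so the two cannot be told apart. Compound 3 `COc1cc(C)cc(-c2c(-c3ccnc(-c4ccc(N(C)C)cc4)c3)cnn2CC#N)c1` is compound 1 with one change: dimethylamino in place of acetyl on an aromatic carbon. Going by the values given here, no measured pair differs in just this way, so nothing directly shows what the change does. Compound 2 carries the dimethylamino group on another core and gives 83%. On that basis the step of a number 2 percentage points higher from compound 1 to compound 3 (within the scatter) is expected to stay within the scatter. Compound 3 is estimated at 82%, ranging from 70% to 95%.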

Compound 3, a percentage reported as activity, at one concentration (the size of the read-out at that concentration, not a potency): 88%
Estimate against measurement, compound 3: 6 percentage points below; measured number inside the range.
By their numbers in this assay, from the lowest: compounds 1, 2 and 3 (each within the scatter of the next).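

Going by these compounds alone, the first direct comparison at this position comes from this assay, where changing 4-acetylphenyl to 4-(dimethylamino)phenyl on the shared core is a number 8 percentage points higher from compound 1 to compound 3 (within the scatter), so the two groups cannot be told apart here. What had rested on a dimethylamino group carried by another core now rests on a pair differing in this one place. Nothing at hand offers an explanation for this result. Open, on these data alone, is whether a carboxylic acid, a morpholine or a longer chain at this position would give a step beyond the scatter.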